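The compounds below may be only part of what the source reports. "The series", "measured", "known", "first", "only" and "open" are said of these compounds alone.

The series shares one core, seen in compound 1 `C=C1C[C@]23C[C@@]1(O)CC[C@H]2c1ccc(OS(=O)(=O)c2ccc(C)cc2)c(C)c1[C@@H]3Cn1cc(-c2ccc(OC)cc2)nn1`. In a functional assay on SW480 cells (Homo sapiens) for cytotoxicity, read by MTT assay, with a stated time of 4 days (a higher number here means a weaker inhibitor, a lower number a stronger inhibitor), compound 1 gives only a limit, > 20000 nM. Compound 2 `C=C1C[C@]23C[C@@]1(O)CC[C@H]2c1ccc(O)c(C)c1[C@@H]3Cn1cc(-c2ccc(OC)cc2)nn1` carries hydrogen in place of (4-methylphenyl)sulfonyl on an oxygen on an aromatic ring. In this assay compound 2 likewise gives only a limit, > 20000 nM. The step that the two limits leave unreadable from compound 1 to compound 2 cannot be read. Compound 3 `C=C1C[C@]23C[C@@]1(O)CC[C@H]2c1cc(Br)c(O)c(C)c1[C@@H]3Cn1cc(-c2ccccc2)nn1` is a further analogue of the same core. In this assay compound 3 also gives only a limit, > 20000 nM. Among the compounds with values here, compound 2 thus stands at the same limit as every other measured compound, as described by the limit of > 20000 nM in this assay, at which 3 of the 3 values shown sit; none of the three values is a number, and no compound can be called stronger or weaker than another.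

Compound 4 `C=C1C[C@]23C[C@@]1(O)CC[C@H]2c1ccc(O)c(C)c1[C@@H]3Cn1cc(-c2ccccn2)nn1` differs from compound 2 in one place: pyridin-2-yl in place of 4-methoxyphenyl on an aromatic carbon. Within the data shown here, no measured step bears directly on this change; the one step, a step that the two limits leave unreadable from compound 1 to compound 2, touches a different position and is itself unreadable. Because the limit of > 20000 nM in this assay, at which 3 of the 3 values shown sit, places all three values at the limit, compound 4 is expected to give only a limit as well. The step from compound 2 to compound 4 is expected to be a step that the limit leaves unreadable from compound 2 to compound 4. For compound 4 the estimate in this assay is 30000 nM, with a range from 8000 nM to 100000 nM.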

Compound 4, half-maximal inhibitory concentration: > 20000 nM
Compound 4 gave a limit, no number; the forecaster's own chance of this, stated with the estimate: 80%; the middle value does not contradict the limit.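

Compound 2 and compound 4 both give only a limit in this assay, so the step between them cannot be read. The compounds shown leave open whether any change on the shared core would give a readable number in this assay, and how pyridin-2-yl and 4-methoxyphenyl compare there.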